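Allyl to phenyl on the thiourea nitrogen

This account rests on a few compounds, and the source may have more. Where it says the series, first, only, none or still open, it means among the compounds named here.

Three compounds of the series have numbers in a functional assay on the whole organism (blood, strain albino) with Mus musculus as the target, with stated times of 6 days and 4 h, at a dose of 0.4 mmol/kg by the oral route; a higher number here means more inhibition at the dose given (going by the name of the read-out), a lower number less inhibition. Compound 1 `CCCNC(=S)NS(=O)(=O)c1ccc(-n2nc(C)cc2C)cc1` gives a limit of the assay, < 1%, and not a number. Compound 2 `Cc1cc(C(=O)O)nn1-c1ccc(S(=O)(=O)NC(=S)Nc2ccccc2)cc1` gives 0% in this assay. Compound 3 `C=CCNC(=S)NS(=O)(=O)c1ccc(-n2nc(C)cc2C)cc1` gives -1% in this assay, the lowest of the two numbers; compound 2 sits one point higher, within the scatter. The third value, that of compound 1, is a limit of the assay.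

For the measured compounds named here, the one change between measured compounds, a step that the limit leaves unreadable from compound 1 to compound 3, cannot be sized, because the limit of < 1% in this assay, at which 1 of the 3 values shown sits, leaves it unreadable. Going by the values given here, no measured step covers the change from compound 3 to compound 4 `Cc1cc(C)n(-c2ccc(S(=O)(=O)NC(=S)Nc3ccccc3)cc2)n1`, which is phenyl in place of allyl on an amide-type nitrogen. Compound 2 already carries phenyl on an amide-type nitrogen, with a different core, and its number in this assay sits with that of compound 3 within the scatter. Nothing among the shown values therefore points to a step beyond the scatter in either direction.

For compound 4 a value of 0% is expected in this assay, within -10% to 10%. The step this estimate means, a number 1 percentage points higher from compound 3 to compound 4 (within the scatter), is expected to stay inside the scatter.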

Compound 4, a percentage reported as inhibition, in the whole organism at one dose (the size of the read-out at that dose, not a potency): -3%
The estimate for compound 4 lay 3 percentage points above the measured number; measured number inside the range.
By their numbers in this assay, from the lowest: compounds 4, 3 and 2 (each within the scatter of the next).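

In this assay, for the compounds shown here, the first readable step on an amide-type nitrogen whose other neighbours are thiocarbonyl carbon, phenyl in place of allyl gives a number 2 percentage points lower from compound 3 to compound 4 (within the scatter), so replacing the open chain with a six-membered aromatic ring brings no change that can be told from the scatter. With phenyl on that nitrogen in both compounds, methyl in place of carboxy on an aromatic carbon gives a number 3 percentage points lower from compound 2 to compound 4 (within the scatter), which shows that this second site also brings no readable change in this assay. Compound 1 gives < 1%, a limit of the assay and not a number, so the step from it to compound 4 cannot be read: the limit of < 1% in this assay, at which 1 of the 4 values shown sits.

Still open, going by these compounds, is whether benzyl, a longer chain or a chain ending in an amine on the same nitrogen would give a step beyond the scatter in this assay. The compounds shown also leave open whether any substituent on the aromatic ring that carries the sulfonyl group would separate a compound from compound 2, compound 3 and compound 4, which all lie within the scatter of one another.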